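Methyl for Methoxy on the Benzothiazole, Second Core

The source may hold more compounds than are shown below. What is called first, only, known or untested is meant among the compounds shown, and "the series" means these compounds.

Compound 2 `COc1ccc2nc(NC(=O)CNC(=O)c3nn(-c4ccccc4)c(=O)c4ccccc34)sc2c1` and compound 1 `Cc1ccc2nc(NC(=O)CNC(=O)c3nn(-c4ccccc4)c(=O)c4ccccc34)sc2c1` share one core and differ in a single group. In an assay on L cells for inhibition of Protein-serine O-palmitoleoyltransferase porcupine (Mus musculus), read by reporter gene assay, with a stated time of 24 h (a lower number here means that less compound is needed, a higher number that more compound is needed for the effect), compound 2 gives 210 nM, and compound 1 gives 35 nM. The change between them is methyl in place of methoxy on an aromatic carbon, and it produced a 6.0-fold lower number from compound 2 to compound 1 (0.78 log units; beyond the scatter).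

Compound 3 `COc1ccc2nc(NC(=O)CSc3nc4c(c(=O)n3-c3ccccc3OC)SCC4)sc2c1` carries a different core; the difference between the two cores is not broken down here. In this assay compound 3 gives 50 nM, which lies within the scatter of the number for compound 1 and beyond it relative to compound 2.

Compound 4 `COc1ccccc1-n1c(SCC(=O)Nc2nc3ccc(C)cc3s2)nc2c(c1=O)SCC2` is not yet measured. It differs from compound 3 by methyl in place of methoxy on an aromatic carbon, the same change that separates compound 2 from compound 1, made on the same kind of position of the same ring. Among the compounds with values here, whether this change carries the same weight on the second core cannot be read from the data, since the cores are not compared in a counted way and only two examples of the change exist.

The step from compound 3 to compound 4 in this assay is expected to be a 4.2-fold lower number from compound 3 to compound 4 (0.62 log units; beyond the scatter), a little less than the shown step because a 6.0-fold lower number from compound 2 to compound 1 (0.78 log units; beyond the scatter) comes from a different core and the single example leaves room for drift. Compound 4 is therefore estimated at 12 nM, with a likely range from 4 nM to 40 nM.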

Compound 4, half-maximal effective concentration: 25 nM
Compound 4: middle estimate off by 2.1-fold (0.32 log units), on the low side, and the stated range covers the measured number.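

In this assay, replacing 6-methoxy-1,3-benzothiazol-2-yl with 6-methyl-1,3-benzothiazol-2-yl on the core of compound 3 gives a 2.0-fold lower number from compound 3 to compound 4 (0.30 log units; within the scatter), so on this core the two numbers cannot be told apart. Set beside the earlier step, the size of the effect did not carry over from one core to the other: the same change on two cores in this assay, a 6.0-fold lower number (0.78 log units; beyond the scatter) from compound 2 to compound 1 and a 2.0-fold lower number (0.30 log units; within the scatter) from compound 3 to compound 4, 3.0-fold (0.48 log units) apart, beyond the scatter of two such steps This shows that, in this series, the step seen on one core is not a reliable guide to the size of the step on the other, but it rests on only two pairs and does not show what in the cores sets the gap or how the change would read on a third core.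

The compounds shown hold only methoxy and methyl at this place, which leaves open whether a fluorine, a chlorine, a nitrile or an amine there would read alike on both cores. Compound 3 and compound 4 also carry a second methoxy group elsewhere, absent from compound 1 and compound 2, and the compounds shown do not separate that group from the rest of the difference between the cores.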